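The source may hold more compounds than are shown below. What is called first, only, known or untested is meant among the compounds shown, and "the series" means these compounds.

Compound 2 `COc1cc2c(Oc3ccc(NC(=O)c4nn(-c5ccc(Cl)cc5)c(=O)cc4C)cc3F)ccnc2cc1OCCCN1CCCCC1` is the starting point of this step. In a functional assay on A549 cells (Homo sapiens) for inhibition, read by MTT assay, with a stated time of 72 h (on this read-out higher numbers stand for weaker inhibition and lower numbers for stronger inhibition), compound 2 gives 320 nM. Going by the values given here, its only measured companion is compound 1 `COc1cc2c(Oc3ccc(NC(=O)c4nn(-c5ccc(Cl)cc5)c(=O)cc4C)cc3F)ccnc2cc1OCCCN1CCCC1`, which in this assay gives 230 nM. Compound 2 thus stands as the higher of two numbers, but the two lie within the usual scatter of each other, so no real separation between them can be claimed. Among the compounds with values here, the single measured step, a 1.4-fold higher number from compound 1 to compound 2 (0.14 log units; within the scatter), shows how little the read-out moved when the ring at the end of the chain grew by one carbon.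

Compound 3 `COc1cc2c(Oc3ccc(NC(=O)c4nn(-c5ccc(Cl)cc5)c(=O)cc4C)cc3F)ccnc2cc1OCCCN1CCC(C)CC1` has not yet been measured. It differs from compound 2 by methyl in place of hydrogen on a saturated ring carbon. This is a small addition to the same ring that the earlier step altered. Because a 1.4-fold higher number from compound 1 to compound 2 (0.14 log units; within the scatter) stayed within the scatter, the step expected here, a 1.1-fold higher number from compound 2 to compound 3 (0.04 log units; within the scatter), is also not expected to go beyond the scatter in either direction. Compound 3 is therefore estimated to give about 350 nM in this assay, with a likely range from 150 nM to 800 nM.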

Compound 3, half-maximal inhibitory concentration: 210 nM
Beside the measured number, compound 3's estimate is 1.7-fold (0.22 log units) above it; the measured number falls inside the stated range.
By their numbers in this assay, from the lowest: compounds 3, 1 and 2 (each within the scatter of the next).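

In this assay, going by these compounds alone, the earlier compounds varied only the size of the ring at the end of the chain, whereas this result adds a group to that ring, and placing a methyl three ring bonds from the ring nitrogen gives a 1.5-fold lower number from compound 2 to compound 3 (0.18 log units; within the scatter) and so does not move the read-out beyond the scatter. Replacing pyrrolidin-1-yl with 4-methylpiperidin-1-yl gives a 1.1-fold lower number from compound 1 to compound 3 (0.04 log units; within the scatter) and again stays within the scatter, so all three end groups shown are indistinguishable in this read-out, and neither ring size nor this single methyl separates them. No available evidence explains why the numbers stay so close.

The compounds shown leave open whether this position would remain as undemanding with something other than a single methyl on the ring, such as a hydroxyl group, a phenyl ring or a second ring nitrogen as in piperazin-1-yl. They also leave open whether a methyl elsewhere on the piperidine ring, or a longer chain between the oxygen and the ring, would produce a step beyond the scatter.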